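This account rests on a few compounds, and the source may have more. Where it says the series, first, only, none or still open, it means among the compounds named here.

Measured in a functional assay on HEL cells (Homo sapiens); a lower number here means that less compound is tolerated, a higher number that more compound is tolerated:
- compound 1 `COC(=O)CNC1=CS(=O)(=O)O[C@@]12[C@@H](CO[Si](C)(C)C(C)(C)C)O[C@@H](n1cc(C)c(=O)n(C)c1=O)[C@@H]2O[Si](C)(C)C(C)(C)C`: 160000 nM
- compound 2 `Cc1cn([C@@H]2O[C@H](CO[Si](C)(C)C(C)(C)C)[C@@]3(OS(=O)(=O)C=C3NC(=O)c3ccccc3)[C@H]2O[Si](C)(C)C(C)(C)C)c(=O)n(C)c1=O`: 9700 nM
- compound 3 `COC(=O)C(=O)CNC1=CS(=O)(=O)O[C@@]12[C@@H](CO[Si](C)(C)C(C)(C)C)O[C@@H](n1cc(C)c(=O)n(C)c1=O)[C@@H]2O[Si](C)(C)C(C)(C)C`: > 200000 nM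

Compound 3 gives only a limit of the assay, > 200000 nM, and no number. It therefore sits at the tolerated end of the series, level with compound 1 as far as the data show, since an at least 1.2-fold higher number from compound 1 to compound 3 (0.09 log units; that floor lies within the scatter) has a floor within the scatter.

The next compound is compound 4 `Cc1cn([C@@H]2O[C@H](CO[Si](C)(C)C(C)(C)C)[C@@]3(OS(=O)(=O)C=C3NCCC(=O)OCc3ccccc3)[C@H]2O[Si](C)(C)C(C)(C)C)c(=O)n(C)c1=O`. Here (benzyloxycarbonyl)methyl replaces (methoxycarbonyl)carbonyl on a saturated chain carbon bound to an amine nitrogen: (benzyloxycarbonyl)methyl in place of (methoxycarbonyl)carbonyl on a saturated chain carbon bound to an amine nitrogen.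

The ester-bearing chains of compound 1 and compound 3 are the closest precedents, and they show little separation. Going by the values given here, the only large steps involve benzoyl: a 16-fold lower number from compound 1 to compound 2 (1.22 log units; beyond the scatter) and an at least 20-fold higher number from compound 2 to compound 3 (1.31 log units; beyond the scatter). Compound 4 keeps an ester chain but also brings in an aromatic ring, so it is expected to fall between these precedents. A lower number is expected in this assay, with an estimated step of an at least 4.0-fold lower number from compound 3 to compound 4 (0.60 log units; beyond the scatter). For compound 4 the expected value is 50000 nM, with an estimated range of 10000 nM to 200000 nM.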

Compound 4, half-maximal cytotoxic concentration: 200000 nM
Beside the measured number, compound 4's estimate is 4.0-fold (0.60 log units) below it; low and high end bracket the measured number.
By their numbers in this assay, from the lowest: compound 2; then compounds 1 and 4 (each within the scatter of the next).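

In this assay the data give a number no higher from compound 3 to compound 4 (the limit leaves the size open), and a six-membered aromatic ring alone does not go with the low number of compound 2. Compound 4 also carries such a ring, within its 2-(benzyloxycarbonyl)ethyl chain, and the change from benzoyl gives a 21-fold higher number from compound 2 to compound 4 (1.31 log units; beyond the scatter). The benzyl ester chain also stands level with the methyl ester chain of compound 1, as a 1.3-fold higher number from compound 1 to compound 4 (0.10 log units; within the scatter) shows. The size of the step from compound 3 to compound 4 cannot be read because compound 3 stands only at a limit: the limit of > 200000 nM in this assay, at which 1 of the 4 values shown sits.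

Going by these compounds, whether the low number of compound 2 goes with the carbonyl of benzoyl on the amine nitrogen or with the benzoyl group as a whole stays open. On these data alone, how a carboxylic acid in place of the ester, or a simple benzyl group on the amine nitrogen, would read in this assay also stays open.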